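The source may hold more compounds than are shown below. What is called first, only, known or untested is meant among the compounds shown, and "the series" means these compounds.

Measured compounds:
compound 1 `Cn1ccc2ccc(-c3cc(Nc4ccccc4S(N)(=O)=O)cc4nccnc34)cc21` 0.5 h
compound 2 `CN(C)S(=O)(=O)c1ccccc1Nc1cc(-c2ccc3ccn(C)c3c2)c2nccnc2c1` 0.233 h
compound 3 `Cn1cc(NC(=O)c2ccncc2Nc2cc(-c3ccc4ccn(C)c4c3)c3nccnc3c2)cn1` 0.2 h

In an ADME assay on microsomes from liver (Mus musculus, strain CD-1) for metabolic stability, read by LC-MS, tested at 2 uM (on this read-out higher numbers stand for a longer-lived compound and lower numbers for a shorter-lived compound), compound 1 gives 0.5 h, compound 2 gives 0.233 h and compound 3 gives 0.2 h. Compound 3 holds the lowest of the three numbers; its gap to compound 2 is within the scatter, its gap to compound 1 is beyond it. Among the measured compounds shown here, the single step recorded within the set, a 2.1-fold lower number from compound 1 to compound 2 (0.33 log units; beyond the scatter), is modest and concerns a sulfonyl group absent from compound 3.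

Compound 4 `CN1CC(NC(=O)c2ccncc2Nc2cc(-c3ccc4ccn(C)c4c3)c3nccnc3c2)C1` has not yet been measured in this assay. It differs from compound 3 at one place: 1-methylazetidin-3-yl in place of 1-methyl-1H-pyrazol-4-yl on an amide-type nitrogen. For the measured compounds named here, no measured step touches an amide-type nitrogen or exchanges a ring of this kind, so nothing in the set speaks to the direction of this change. Going by the values given here, the whole series sits in a narrow, short-lived band, and the one known step is small. On that basis no step beyond the scatter is expected for a 1.3-fold higher number from compound 3 to compound 4 (0.10 log units; within the scatter). Compound 4 is therefore estimated at 0.25 h, with a range from 0.1 h to 0.6 h, pending the actual read-out.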

Compound 4, half-life: > 1 h
Compound 4 gave a limit, no number; the forecaster's own chance of this, stated with the estimate: 5%; at least 4.0-fold (0.60 log units) between middle value and limit.
By their numbers in this assay, from the lowest: compounds 3 and 2 (each within the scatter of the next); then compound 1. At a limit, above all of these: compound 4.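

Compound 4 gives > 1 h in this assay, which is a limit of the assay and not a number. The substituent on the amide-type nitrogen therefore matters to the half-life: 1-methylazetidin-3-yl in place of 1-methyl-1H-pyrazol-4-yl gives an at least 5.0-fold higher number from compound 3 to compound 4 (0.69 log units; beyond the scatter), so this place can lift a compound out of the short-lived range held by compound 2 and compound 3. The step has a lower bound but no upper end in these data: the limit of > 1 h in this assay, at which 1 of the 4 values shown sits.

Going by these compounds, it remains open whether the change follows the non-aromatic ring or its nitrogen; a cyclobutyl group, with no ring nitrogen, and a 1-methylpiperidin-4-yl group on the same amide-type nitrogen would help separate the two. Also open, on these data alone, is whether an azetidine without the methyl group keeps the longer half-life.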